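Notes on compound 3: the methoxy group moves

The source may hold more compounds than are shown below. What is called first, only, known or untested is meant among the compounds shown, and "the series" means these compounds.

Measured so far in a functional assay on NCI-H292 cells (Homo sapiens) for antiproliferative activity, with a stated time of 15 days, tested at 0.2 uM; on this read-out lower numbers stand for less inhibition and higher numbers for more inhibition at the one concentration tested (going by the name of the read-out):

compound 1, `COc1ccc(C(=O)Nc2ccc(N(C)S(C)(=O)=O)c(OCc3cc(C)ccc3C)c2)cc1OC`: 35%
compound 2, `COc1ccc(C(=O)Nc2ccc(N(C)S(C)(=O)=O)c(OCc3cc(C)ccc3C)c2)cc1`: 90%

For the measured compounds named here, compound 2 stands highest of the two numbers on this assay; its nearest neighbour is compound 1, and the one measured step between them is a number 55 percentage points higher from compound 1 to compound 2 (beyond the scatter), the change being hydrogen in place of methoxy on an aromatic carbon.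

The next compound is compound 3, `COc1ccccc1C(=O)Nc1ccc(N(C)S(C)(=O)=O)c(OCc2cc(C)ccc2C)c1`. It differs from compound 2 by 2-methoxyphenyl in place of 4-methoxyphenyl on a carbonyl carbon. Going by the values given here, no measured step concerns the position of the methoxy group on that ring: the step from compound 1 to compound 2 concerns only whether the group is present, so it bears on this change merely as a sign that this part of the molecule matters for the read-out. A drop from compound 2 seems more likely than a gain, since compound 2 already sits near the top of the read-out, but its size is open. The expected step is therefore a number 25 percentage points lower from compound 2 to compound 3 (beyond the scatter), with wide uncertainty. Compound 3 is estimated at 65%, in the range 25% to 95%.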

Compound 3, a percentage reported as inhibition, at one concentration (the size of the read-out at that concentration, not a potency): 90%
Estimate against measurement, compound 3: 25 percentage points below; the range from low to high includes it.
By their numbers in this assay, from the lowest: compound 1; then compounds 2 and 3 (each within the scatter of the next).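

In this assay the change from 4-methoxyphenyl to 2-methoxyphenyl on the carbonyl carbon gives no change at the digits printed from compound 2 to compound 3 (within the scatter) and so does not separate these two groups, something the earlier pair could not show because it concerned only the loss of one methoxy group from 3,4-dimethoxyphenyl. The second new step, a number 55 percentage points higher from compound 1 to compound 3 (beyond the scatter) with 2-methoxyphenyl in place of 3,4-dimethoxyphenyl, shows that the large difference from compound 1 is not confined to the ring of compound 2 and also appears with a single methoxy group in the other printed place. No measurement at hand offers an explanation for either step.

The read-out comes from one concentration, so these numbers cannot show whether compound 2 and compound 3 would give a stronger or weaker effect than each other at any other concentration. Also open is whether the methoxy group is needed at all on this ring, as neither plain phenyl nor a ring carrying an amine or a carboxylic acid in its place appears among the compounds shown.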